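The source may hold more compounds than are shown below. What is called first, only, known or untested is meant among the compounds shown, and "the series" means these compounds.

Within the data shown here, compound 1 `COc1cc(NC(=O)Nc2cc(Nc3ccc(C(C)(C)C)cc3)ncn2)cc(OC)c1` is one of three compounds measured in a functional assay on PC-9 cells (Homo sapiens) for inhibition, read by MTT assay, with a stated time of 48 h, tested at 10 uM (a higher number here means more inhibition at the concentration tested (going by the name of the read-out), a lower number less inhibition), where compound 1 gives 74.1%. Compound 2 `COc1cc(NC(=O)Nc2cc(Nc3ccc(F)c(Cl)c3)ncn2)cc(OC)c1` gives 77.5%, a change of a number 3.4 percentage points higher from compound 1 to compound 2 (within the scatter). Compound 3 `COc1cc(NC(=O)Nc2cc(Nc3cc(F)ccc3OC)ncn2)cc(OC)c1` gives 59.5%, a drop of a number 14.6 percentage points lower from compound 1 to compound 3 (beyond the scatter); the step of a number 18 percentage points lower from compound 2 to compound 3 (beyond the scatter) points the same way. Compound 1 thus stands second highest of the three, level with compound 2 and clearly above compound 3. Compound 4 `CC(C)(C)c1ccc(Nc2cc(NC(=O)Nc3c(Cl)cccc3Cl)ncn2)cc1` differs from compound 1 by 2,6-dichlorophenyl in place of 3,5-dimethoxyphenyl on an amide-type nitrogen. All three measured steps alter the group on the nitrogen on an aromatic ring, not the group on the amide-type nitrogen, so none of them bears on this change, and no direction is indicated. Compound 4 is expected to show a step of a number 6.1 percentage points lower from compound 1 to compound 4 (within the scatter). Compound 4 is estimated at 68%, in a range from 42% to 86%.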

Compound 4, a percentage reported as inhibition, at one concentration (the size of the read-out at that concentration, not a potency): 41.5%
For compound 4 the middle estimate is 26.5 percentage points above the measured one; the whole stated range lies above it.
By their numbers in this assay, from the lowest: compound 4; then compound 3; then compounds 1 and 2 (each within the scatter of the next).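

Among these compounds, the group on the amide-type nitrogen clearly matters in this assay: putting 2,6-dichlorophenyl in place of 3,5-dimethoxyphenyl gives a number 32.6 percentage points lower from compound 1 to compound 4 (beyond the scatter) and is a large step, whereas the earlier steps, all on the nitrogen on an aromatic ring, were modest or within the scatter. Among the compounds shown here, this is the first sign that this position is sensitive to change. Nothing at hand explains the loss.

As far as these compounds go, whether it reflects gaining the chlorines or losing the methoxy groups remains open, since both changed together. From the compounds shown here alone, how a plain phenyl or a pyridyl group would behave on this nitrogen also remains open.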